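Replacing the piperidine amide with a carboxyethenyl group

The source may report more compounds than this note shows. Statements on the series, on what has been measured and on what is new or still open speak of the compounds shown alone.

Compound 1 `CCN(CC)C(=O)c1nc(-c2ccc(OC)cc2)c(-c2ccc(OC)cc2)s1`: < 10 nM (a limit)
Compound 2 `COc1ccc(-c2nc(C(=O)N=C(N)N)sc2-c2ccc(OC)cc2)cc1`: > 100 nM (a limit)
Compound 3 `COc1ccc(-c2nc(C(=O)N3CCCCC3)sc2-c2ccc(OC)cc2)cc1`: > 1000 nM (a limit)

All three readings in a functional assay with Oryctolagus cuniculus as the target (on this read-out lower numbers stand for stronger inhibition and higher numbers for weaker inhibition), are limits of the assay, not numbers. Compound 3 is known only by its limit of > 1000 nM.

Compound 4 `COc1ccc(-c2nc(/C=C/C(=O)O)sc2-c2ccc(OC)cc2)cc1` carries 2-carboxyethenyl in place of (piperidin-1-yl)carbonyl on an aromatic carbon. Going by the values given here, two measured steps bear on this change: the large at least 100-fold higher number from compound 1 to compound 3 (2.00 log units; beyond the scatter) and the at least modest an at least 10-fold higher number from compound 1 to compound 2 (1.00 log units; beyond the scatter). Both alter only the group on the carbonyl carbon, and a step that the two limits leave unreadable from compound 2 to compound 3 cannot be sized. Among the compounds with values here, no measured step replaces the whole carbonyl group, so the expectation is loose. Only the diethylamino amide of compound 1 reaches the strong end, and compound 4 lacks that group. No recovery towards compound 1 is therefore expected, and the expected change is a step that the limit leaves unreadable from compound 3 to compound 4. For compound 4 the estimated value is 3000 nM, with an expected range from 300 nM to 30000 nM.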

Compound 4, half-maximal inhibitory concentration: > 100 nM
Compound 4: no number, only a limit (the forecaster's own chance of this, stated with the estimate: 70%); the middle value lies beyond the limit too.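

Placed on the aromatic carbon next to the ring nitrogen and the ring sulfur, 2-carboxyethenyl in place of diethylcarbamoyl gives an at least 10-fold higher number from compound 1 to compound 4 (1.00 log units; beyond the scatter) in this assay. This is the first change shown that replaces the whole group on this carbon, not only the part on the carbonyl carbon, and compound 4 does not reach the strong end held by compound 1. The steps to compound 4 from compound 2 and from compound 3 cannot be read, as each joins two limits.

On these data alone, compound 2, compound 3 and compound 4 are known only by limits, so their order stays open. Also open, as far as these compounds go, is whether a small amide such as dimethylamino or pyrrolidin-1-yl on the carbonyl carbon, or a saturated 2-carboxyethyl chain, would fall nearer to compound 1.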